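A few compounds are considered here, and "the series" means these few. Any claim that something is new, unique, unknown or untested is made for them only; others in the source may bear on it.

Three compounds have been measured in a functional assay on the whole organism (artery, strain albino) with Rattus norvegicus as the target, with a stated time of 300 min, at a dose of 10 mg/kg by the oral route; a lower number here means less inhibition, a higher number more inhibition at the dose given (going by the name of the read-out):

compound 1, `CC1=C(C(=O)Nc2ccc(F)cc2)C(c2ccc([N+](=O)[O-])cc2)N=C(SCc2cccc(Cl)c2)N1`, with 18.5%
compound 2, `CC1=C(C(=O)Nc2ccc(F)cc2)C(c2ccc([N+](=O)[O-])cc2)N=C(SCc2ccc(Cl)cc2)N1`, with 37.9%
compound 3, `CC1=C(C(=O)Nc2ccc(Br)cc2)C(c2ccc(Cl)cc2Cl)N=C(SCc2cccc(Cl)c2)N1`, with 18.5%

Compound 1 and compound 2 share one core and differ in a single spot: 4-chlorophenyl in place of 3-chlorophenyl on a saturated chain carbon bound to a sulfur. That change brought a number 19.4 percentage points higher from compound 1 to compound 2 (beyond the scatter), a step that lies beyond the usual scatter of this kind of measurement.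

Compound 3 is built on a different core, and the difference between the two cores is not broken down here. In this assay compound 3 gives a number level with compound 1 at the digits reported, so the two sit together as the lowest of the three values, and compound 2 stands above both.

Compound 4, `CC1=C(C(=O)Nc2ccc(Br)cc2)C(c2ccc(Cl)cc2Cl)N=C(SCc2ccc(Cl)cc2)N1`, has not yet been measured. It is related to compound 3 in exactly the way compound 2 is related to compound 1: 4-chlorophenyl in place of 3-chlorophenyl on a saturated chain carbon bound to a sulfur. Going by the values given here, since the change is the same and sits at the same place, the step from compound 1 to compound 2 is the only guide for what it may do on the core of compound 3. On that basis compound 4 is expected to rise by about a number 16.5 percentage points higher from compound 3 to compound 4 (beyond the scatter) in this assay, a step comparable to a number 19.4 percentage points higher from compound 1 to compound 2 (beyond the scatter), though resting on a single precedent on a different core. Compound 4 is therefore estimated at 35%, with the likely range running from 15% to 55%.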

Compound 4, a percentage reported as inhibition, in the whole organism at one dose (the size of the read-out at that dose, not a potency): 38.5%
Beside the measured number, compound 4's estimate is 3.5 percentage points below it; the range from low to high includes it.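

In this assay, 4-chlorophenyl in place of 3-chlorophenyl on a saturated chain carbon bound to a sulfur gives a number 20 percentage points higher from compound 3 to compound 4 (beyond the scatter), and this step can be set directly beside the one seen earlier on the other core: the same change on two cores in this assay, a number 19.4 percentage points higher (beyond the scatter) from compound 1 to compound 2 and a number 20 percentage points higher (beyond the scatter) from compound 3 to compound 4, 0.6 percentage points apart, within the scatter of two such steps. For a newcomer, this is what transferability looks like: the same small change, made at the same place on two different cores, shifted the read-out by a matching amount, so in these two pairs its effect did not depend on which core carried it. It does not show why the change raises the number, and two pairs cannot establish a rule for every core in the series; the values also describe the size of the effect at a single oral dose and time, which is not a measure of potency.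

On these data alone, all four compounds carry a chlorobenzyl group on the sulfur, so it remains open what a plain benzyl group, or a longer chain ending in an amine, would do in this assay. As far as these compounds go, it is also open whether this swap would give a step of similar size on a core with a carboxylic acid in place of the amide.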